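The compounds below may be only part of what the source reports. "The series", "measured", "known", "first", "only" and "open" are said of these compounds alone.

Measured so far in an ADME assay on HepG2 cells (Homo sapiens) for cytotoxicity, read by MTT assay, with a stated time of 48 h; on this read-out lower numbers stand for higher toxicity in this test and higher numbers for lower toxicity in this test:
- compound 1 `C#CCOc1ccc(-c2noc(NC3CCCCC3)n2)cc1`: 119 ug/mL
- compound 2 `C#CCOc1ccc(-c2noc(N(CC#C)C3CCCCC3)n2)cc1`: a limit, see below

In this assay, among the measured compounds shown here, compound 1 gives 119 ug/mL, the only number in the set. Compound 2 gives only a limit of > 200 ug/mL, not a number. For the measured compounds named here, the single measured step, an at least 1.6-fold higher number from compound 1 to compound 2 (0.22 log units; that floor lies within the scatter), comes from propargyl in place of hydrogen on a nitrogen on an aromatic ring and rests on the limit (the limit of > 200 ug/mL in this assay, at which 1 of the 2 values shown sits), so it sets a floor only.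

Compound 3 `C#Cc1ccc(-c2noc(NC3CCCCC3)n2)cc1` differs from compound 1 by ethynyl in place of propargyloxy on an aromatic carbon. Going by the values given here, the one measured step concerns a different place and carries no direction on the aromatic carbon, so no measured step bears on this change. No step beyond the scatter is therefore expected: the expected step is a 1.1-fold lower number from compound 1 to compound 3 (0.03 log units; within the scatter). Compound 3 is estimated at 110 ug/mL, with a range of 50 ug/mL to 200 ug/mL.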

Compound 3, half-maximal cytotoxic concentration: 54.2 ug/mL
Beside the measured number, compound 3's estimate is 2.0-fold (0.31 log units) above it; the measured number falls inside the stated range.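

The aromatic carbon para to a large group now has a measured direction in this assay: ethynyl in place of propargyloxy gives a 2.2-fold lower number from compound 1 to compound 3 (0.34 log units; beyond the scatter), so this change goes with higher toxicity in this test. Compound 2 stands only as a limit, so the step on the nitrogen gives no size to set against this one. Nothing measured in this set gives a cause for the step on the aromatic carbon.

With one replacement shown at this carbon, it stays open whether the lower number goes with the loss of the oxygen or with the smaller group, and a methoxy group or a longer chain ending in an amine at this place would separate the two. Also open, going by these compounds, is whether propargyl on the nitrogen has the same direction with ethynyl on the aromatic carbon.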